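Benzyl for isopropyl on compound 2

The source may hold more compounds than are shown below. What is called first, only, known or untested is meant among the compounds shown, and "the series" means these compounds.

Compound 1 (`Nc1ccc(S(=O)(=O)c2ccc(-c3ncc(C(O)(C(F)(F)F)C(F)(F)F)cn3)cc2)cn1`) gives < 14 mL.min-1.g-1 as a limit of the assay
Compound 2 (`CC(C)Nc1nc(S(=O)(=O)c2ccc(N)nc2)ccc1-c1ccc(C(C)(O)C(F)(F)F)cn1`) gives 62 mL.min-1.g-1 as a measured number

Both readings come from an ADME assay (liver) for metabolic stability, with Liver microsome (Rattus norvegicus) as the target, using microsomes and NADPH, with a stated time of 30 min, at 37 degrees C, tested at 1 uM (a lower number here means slower removal, a higher number faster removal of the compound), and no others are at hand. For compound 1 the reading is a limit and not a number. Going by the values given here, that leaves compound 2 with the only actual number in the set. Compound 3 (`CC(O)(c1ccc(-c2ccc(S(=O)(=O)c3ccc(N)nc3)nc2NCc2ccccc2)nc1)C(F)(F)F`) has not yet been measured. It carries benzyl in place of isopropyl on a nitrogen on an aromatic ring. Among the compounds with values here, no measured pair shows what such a swap does, so any forecast is loose. A modest rise in removal rate is expected, and it may stay within the usual scatter (a 1.3-fold higher number from compound 2 to compound 3 (0.11 log units; within the scatter)) as estimated here. For compound 3 the expected value in this assay is 80 mL.min-1.g-1 with a range from 35 mL.min-1.g-1 to 180 mL.min-1.g-1 as estimated here.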

Compound 3, intrinsic clearance in microsomes: 114 mL.min-1.g-1
Compound 3: middle estimate off by 1.4-fold (0.15 log units), on the low side, and the stated range covers the measured number.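

In this assay, going by these compounds alone, putting benzyl in place of isopropyl on a nitrogen on an aromatic ring gives a 1.8-fold higher number from compound 2 to compound 3 (0.26 log units; within the scatter) and so provides the only measured step at this position. The step shows that exchanging the 3 heavy atoms of isopropyl for the 7 heavy atoms of benzyl, with its six-membered aromatic ring of carbon only, leaves the two readings within the usual scatter. Nothing at hand bears on the cause of this result.

From the compounds shown here alone, it remains open whether a group of another kind on this nitrogen, such as a longer chain, an amine or a carboxylic acid, would give a step beyond the scatter. Going by these compounds, it is also open whether a fluorine or a methoxy group on the benzyl ring would leave the reading within it.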